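The source may report more compounds than this note shows. Statements on the series, on what has been measured and on what is new or still open speak of the compounds shown alone.

Measured so far:
compound 1 `CCOC(=O)/C=C/c1ccncc1-c1ccc2cc[nH]c2c1`: 2140 nM as the only number
compound 2 `CN1CCN(C(=O)/C=C/c2ccncc2-c2ccc(F)cc2)CC1`: "not determined" (no result reported)

Among the measured compounds shown here, in a functional assay on HCT-116 cells (Homo sapiens) for inhibition, read by MTT assay, with a stated time of 72 h (on this read-out higher numbers stand for weaker inhibition of growth and lower numbers for stronger inhibition of growth), compound 1 gives 2140 nM and, as the only number, has no rank. Compound 2 offers no comparison, as it has no reported result.

Next for testing is compound 3 `O=C(O)/C=C/c1ccncc1-c1ccc2cc[nH]c2c1`, which keeps the core of compound 1. The change is hydrogen in place of ethyl on an oxygen next to a carbonyl group, with hydrogen in place of ethyl on an oxygen next to a carbonyl group, so that ethoxycarbonyl becomes carboxy. For the measured compounds named here, no measured pair shows this change, so any expectation for this assay is a judgement without direct support from the data. A moderate loss of growth inhibition is expected, meaning a higher number than for compound 1, although a result within the usual scatter remains possible. The expected change is a 3.7-fold higher number from compound 1 to compound 3 (0.57 log units; beyond the scatter) as a rough estimate. For compound 3 the estimated value is 8000 nM, with an expected range from 2000 nM to 32000 nM as the likely span.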

Compound 3, concentration for 50% growth inhibition: > 30000 nM
Compound 3: no number, only a limit (the forecaster's own chance of this, stated with the estimate: 15%); at least 3.7-fold (0.57 log units) between middle value and limit.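

Compound 3 gives > 30000 nM in this assay, and this value is a limit, not a number. Going from ethoxycarbonyl to carboxy, with hydrogen in place of ethyl on the oxygen next to the carbonyl group, gives an at least 14-fold higher number from compound 1 to compound 3 (1.14 log units; beyond the scatter); this is the only step in the series so far, and it shows that growth inhibition on this core responds strongly to what sits on that oxygen, with the ethyl ester holding a measurable value and the free carboxy group losing it. The size of the step is only a lower bound, so how much activity remains in compound 3 cannot be read: the limit of > 30000 nM in this assay, at which 1 of the 3 values shown sits.

With only ethyl and hydrogen shown on this oxygen, it remains open whether a longer chain such as propyl or a branched chain such as isopropyl would match or better the value of compound 1, or whether ethyl is already near the best choice. On these data alone, it also remains open how a primary amide would compare at this place on the core of compound 1, and compound 2, with no reported result, adds nothing on that point.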